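The compounds below may be only part of what the source reports. "The series", "measured", "known", "first", "only" and "open" are said of these compounds alone.

Working notes on a small series sharing one core, read in a functional assay on HepG2 cells (Homo sapiens) for antiproliferative activity, read by MTT assay, with a stated time of 48 h; a lower number here means a stronger inhibitor, a higher number a weaker inhibitor. Compound 1 (`N#Cc1cccc(Nc2ncnc3cc(NC(=O)/C=C/c4ccccc4)sc23)c1`) gives 15900 nM, compound 2 (`O=C(/C=C/c1ccccc1)Nc1cc2ncnc(Nc3ccc(F)c(Cl)c3)c2s1`) gives 10600 nM, and compound 3 (`O=C(/C=C/c1ccccc1)Nc1cc2ncnc(Nc3cc(Cl)cc(Cl)c3)c2s1`) gives 10700 nM. Compound 2 does not stand apart from the other two, since all three steps lie within the scatter: a 1.5-fold lower number from compound 1 to compound 2 (0.18 log units; within the scatter), a 1.0-fold higher number from compound 2 to compound 3 (0.00 log units; within the scatter) and a 1.5-fold lower number from compound 1 to compound 3 (0.17 log units; within the scatter).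

Compound 4 (`COc1ccc(/C=C/C(=O)Nc2cc3ncnc(Nc4ccc(F)c(Cl)c4)c3s2)cc1`) differs from compound 2 by one change: methoxy in place of hydrogen on an aromatic carbon, which turns phenyl into 4-methoxyphenyl. The measured steps bear on this only indirectly. For the measured compounds named here, all of them exchange the aryl group on the nitrogen, and none touches this phenyl, so the data offer no measured step at this place and no direction for the change. Going by the values given here, the only guide is the flat series around compound 2, at 10600 nM, so no step beyond the scatter is expected in this assay, though the range is kept wide. The expected result is a 1.2-fold lower number from compound 2 to compound 4 (0.07 log units; within the scatter). Compound 4 is estimated at 9000 nM, with an expected range of 3500 nM to 20000 nM.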

Compound 4, half-maximal inhibitory concentration: 13900 nM
The estimate for compound 4 lay 1.5-fold (0.19 log units) below the measured number, and the stated range covers the measured number.
By their numbers in this assay, from the lowest: compounds 2, 3, 4 and 1 (each within the scatter of the next).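

For the compounds shown here, the only step at this phenyl reads a 1.3-fold higher number from compound 2 to compound 4 (0.12 log units; within the scatter) in this assay, so the flat picture now extends beyond the aryl group on the nitrogen to a second place on the molecule. Like the exchanges at that nitrogen, phenyl to 4-methoxyphenyl stays within the scatter, and methoxy on this aromatic carbon, para to a large group, leaves the number essentially unchanged. Nothing available bears on why the number holds at this position.

A single substituent cannot show whether this place is insensitive in general: an amine, a carboxylic acid or a longer chain such as butoxy on the same carbon could still move the number. Also open, going by these compounds, is whether methoxy would read the same with 3-cyanophenyl or 3,5-dichlorophenyl on the nitrogen.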